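Working notes: chain length and cytotoxicity in one series

This account rests on a few compounds, and the source may have more. Where it says the series, first, only, none or still open, it means among the compounds named here.

Compound 1 `CCCCCCCCNC(=O)[C@@H](NC(=O)c1cccs1)[C@@H](C)O`: 149000 nM
Compound 2 `CCCCCCCCCCCCNC(=O)[C@@H](NC(=O)c1cccs1)[C@@H](C)O`: 30100 nM
Compound 3 `CCCCCCCCCCCCCCNC(=O)[C@@H](NC(=O)c1ccccc1)[C@@H](C)O`: 54200 nM

All three numbers come from a functional assay on HepG2 cells (Homo sapiens) for cytotoxicity, read by MTT assay, with a stated time of 48 h; on this read-out higher numbers stand for weaker inhibition and lower numbers for stronger inhibition. Going by the values given here, the one change measured twice over is butyl in place of hydrogen on a saturated chain carbon, eight bonds along the chain from an amide-type nitrogen, which in this assay reads a 5.0-fold lower number from compound 1 to compound 2 (0.69 log units; beyond the scatter). Compound 4 `CCCCCCCCCCCCCCCCCCNC(=O)[C@@H](NC(=O)c1ccccc1)[C@@H](C)O` is not yet measured; it differs from compound 3 by butyl in place of hydrogen on a saturated chain carbon, ten or more bonds along the chain from an amide-type nitrogen. The place is not the same word for word: eight bonds along the chain from an amide-type nitrogen in the first pair, and a different stretch of the chain in the second, as the two descriptions show, so this is the same kind of change, not the same one. The difference between the core of compound 1 and the core of compound 3 is not broken down here. Compound 3 lies within the scatter of compound 2 and beyond it from compound 1.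

Among the compounds with values here, with only one precedent, and that on a shorter chain, a smaller step is expected from compound 3 to compound 4, a 2.2-fold lower number from compound 3 to compound 4 (0.34 log units; beyond the scatter), resting on a 5.0-fold lower number from compound 1 to compound 2 (0.69 log units; beyond the scatter). Compound 4 is thus estimated at 25000 nM, expected between 8000 nM and 80000 nM.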

Compound 4, half-maximal inhibitory concentration: > 400000 nM
Compound 4: a limit, no number (the forecaster's own chance of this, stated with the estimate: 10%); middle value at least 16-fold (1.20 log units) from the limit.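

Compound 4 reads > 400000 nM in this assay, a limit of the assay and not a number. The new step is an at least 7.3-fold higher number from compound 3 to compound 4 (0.86 log units; beyond the scatter), opposite in direction to the earlier one, so the butyl change does not carry over from the core of compound 1 to the core of compound 3: the same change on two cores in this assay, a 5.0-fold lower number (0.69 log units; beyond the scatter) from compound 1 to compound 2 and an at least 7.3-fold higher number (0.86 log units; beyond the scatter) from compound 3 to compound 4, at least 36-fold (1.56 log units) apart, beyond the scatter of two such steps The core and the place on the chain change together across the two pairs, so these compounds do not separate the two, and the true size of the new step stays unknown at the limit: the limit of > 400000 nM in this assay, at which 1 of the 4 values shown sits.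

Open, going by these compounds, is how a longer chain on the core of compound 1 would read. Also open, on these data alone, is whether an amine in place of the butyl would read like compound 3 or like compound 4.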